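Replacing trifluoromethoxy with fluoro: working notes

The compounds below may be only part of what the source reports. "The series", "measured", "known", "first", "only" and "open" are said of these compounds alone.

Values so far in a physicochemical assay for solubility, at pH 7.4; a lower number here means a less soluble compound, a higher number a more soluble compound
- compound 1 `C[C@H](C#Cc1cccc(C(=O)NCCC(c2ccc(F)cc2)c2ccc(C(F)(F)F)cc2)c1)N(O)C(N)=O` gives 3000 nM
- compound 2 `C[C@H](C#Cc1cccc(C(=O)NCCC(c2ccc(F)cc2)c2ccc(OC(F)(F)F)cc2)c1)N(O)C(N)=O` gives 10000 nM

Compound 2 holds the highest of the two numbers. Compound 3 `C[C@H](C#Cc1cccc(C(=O)NCCC(c2ccc(F)cc2)c2ccc(F)cc2)c1)N(O)C(N)=O` carries fluoro in place of trifluoromethoxy on an aromatic carbon and awaits measurement. For the measured compounds named here, the one measured step at this carbon, a 3.3-fold higher number from compound 1 to compound 2 (0.52 log units; beyond the scatter) and so modest, bears on the change only loosely. Going by the values given here, no measured compound carries fluoro at this carbon, so the direction remains open. The expected change in this assay is a 1.2-fold higher number from compound 2 to compound 3 (0.08 log units; within the scatter) and so stays within the scatter. The estimate for compound 3 is 12000 nM with 4000 nM to 35000 nM as its expected range.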

Compound 3, solubility: 3000 nM
Compound 3: middle estimate off by 4.0-fold (0.60 log units), on the high side; the measured number lies below the stated range.
By their numbers in this assay, from the lowest: compounds 1 and 3 (each within the scatter of the next); then compound 2.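

In this assay, fluoro in place of trifluoromethoxy on this aromatic carbon gives a 3.3-fold lower number from compound 2 to compound 3 (0.52 log units; beyond the scatter). Fluoro in place of trifluoromethyl gives no change at the digits printed from compound 1 to compound 3 (within the scatter), so of the three groups seen at this carbon, trifluoromethoxy alone stands apart, and the earlier step now reads as specific to that group. No available data explain this difference.

Still open, on these data alone, is whether a methoxy, an amine or a carboxylic acid at this carbon would match compound 2 or exceed it. Also open, as far as these compounds go, is whether trifluoromethoxy gives a similar step on the other aromatic ring of the shared core.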